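Pyrazole dihydroxyheptanoic acid series: amide variation

The source may report more compounds than this note shows. Statements on the series, on what has been measured and on what is new or still open speak of the compounds shown alone.

Measured compounds:
compound 1 `CC(C)c1c(C(=O)N(C)Cc2cccc(F)c2)nn(-c2ccc(F)cc2)c1CC[C@@H](O)C[C@@H](O)CC(=O)O`: 1900 nM
compound 2 `COc1ccc(CNC(=O)c2nn(-c3ccc(F)cc3)c(OC[C@@H](O)C[C@@H](O)CC(=O)O)c2C(C)C)cc1`: "not determined" (no result reported)

In a functional assay on L6 cells (Rattus norvegicus) for inhibition (on this read-out higher numbers stand for weaker inhibition and lower numbers for stronger inhibition), compound 1 gives 1900 nM. Going by the values given here, compound 2 stands without a number, as the result of compound 2 in this assay was not determined, so no step between measured compounds can be computed. Compound 3 `CC(C)c1c(C(=O)N(C)Cc2ccc(F)cc2)nn(-c2ccc(F)cc2)c1OC[C@@H](O)C[C@@H](O)CC(=O)O` differs from compound 2 as follows: (4-fluorobenzyl)(methyl)amino in place of (4-methoxybenzyl)amino on a carbonyl carbon. With no step shown, the size of the change in this assay cannot be read from the data, and only compound 1 offers a reference point. For compound 3 in this assay a value of 1500 nM is estimated, within a range of 400 nM to 6000 nM.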

Compound 3, half-maximal inhibitory concentration: 2800 nM
Compound 3: middle estimate off by 1.9-fold (0.27 log units), on the low side; measured number inside the range.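

No step can be read in this assay: compound 2 carries no number, and compound 3 at 2800 nM has no measured partner differing in one place. On these data alone, the effect of the amide change on inhibition stays open. No evidence bears on this result.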